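This account rests on a few compounds, and the source may have more. Where it says the series, first, only, none or still open, it means among the compounds named here.

Compound 3 `COc1ccccc1Oc1ccc2c(NCCCNCc3cccc(OC)c3O)ccnc2c1` gives 14500 nM in a physicochemical assay for solubility, with a stated time of 18 h, at pH 7.4; on this read-out lower numbers stand for lower solubility and higher numbers for higher solubility. Compound 1 `COc1ccc(F)cc1CNCCCNc1ccnc2cc(Oc3ccc(F)cc3)ccc12` gives 14500 nM in this assay, level with compound 3 at the digits shown, and the two together hold the lowest of the three numbers in hand. Compound 2 `COc1ccc(-c2ccc3c(NCCCNCc4cc(F)ccc4OC)ccnc3c2)cc1` gives 32000 nM in this assay. Within the data shown here, the one step within the set, a 2.2-fold higher number from compound 1 to compound 2 (0.34 log units; beyond the scatter), concerns the shared core and not the saturated chain carbon bound to an amine nitrogen.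

Compound 4 `COc1ccc(F)cc1CNCCCNc1ccnc2cc(Oc3ccccc3OC)ccc12` is not yet measured. It differs from compound 3 by 5-fluoro-2-methoxyphenyl in place of 2-hydroxy-3-methoxyphenyl on a saturated chain carbon bound to an amine nitrogen. Among the measured compounds shown here, no measured step covers this exchange. Compound 4 carries the same 5-fluoro-2-methoxybenzyl group as compound 1 and the same group on the core as compound 3, and the numbers for compound 1 and compound 3 do not differ at the digits shown, so a step beyond the scatter is not expected. For compound 4 the expected step is no change at the digits printed from compound 3 to compound 4 (within the scatter). Compound 4 is estimated at 14500 nM, with a range from 7000 nM to 30000 nM.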

Compound 4, solubility: 14500 nM
For compound 4 middle estimate and measured number coincide at the digits printed; low and high end bracket the measured number.
By their numbers in this assay, from the lowest: compounds 1, 3 and 4 (each within the scatter of the next); then compound 2.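

Working from this assay, the exchange at the saturated chain carbon bound to an amine nitrogen now has a measured step: no change at the digits printed from compound 3 to compound 4 (within the scatter), even though the entering group lacks the hydrogen-bond donor counted on 2-hydroxy-3-methoxyphenyl. The group on the core gives a split picture, with no change at the digits printed from compound 1 to compound 4 (within the scatter) for 2-methoxyphenyl in place of 4-fluorophenyl on an oxygen on an aromatic ring, but a 2.2-fold lower number from compound 2 to compound 4 (0.34 log units; beyond the scatter) for 2-methoxyphenoxy in place of 4-methoxyphenyl on an aromatic carbon. No supporting measurement bears on the reason for these steps.

Open, going by these compounds, is whether a carboxylic acid on the aromatic ring, or a cyclohexyl group in its place, would move the number beyond the scatter at this position. Also open, on these data alone, is whether 4-methoxyphenyl on the core gives a comparable step alongside 2-hydroxy-3-methoxyphenyl.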